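The compounds below may be only part of what the source reports. "The series", "measured", "known", "first", "only" and "open" are said of these compounds alone.

Measured so far:
compound 1, `COc1ccc(OC(=O)Nc2ccc([Se]C#N)cc2)cc1`: 4500 nM
compound 2, `CCCCOC(=O)Nc1ccc([Se]C#N)cc1`: 5300 nM

In an ADME assay on 184B5 cells (Homo sapiens) for cytotoxicity, read by MTT assay, with a stated time of 72 h (a higher number here means a weaker inhibitor of growth, a lower number a stronger inhibitor of growth), compound 1 gives 4500 nM and compound 2 gives 5300 nM. Compound 1 has the smaller of the two numbers, but the gap between them lies within the scatter of repeated measurements, so the two cannot be told apart on these data. Compound 3, `N#C[Se]c1ccc(NC(=O)Oc2ccc(F)cc2)cc1`, has not yet been measured in this assay. It differs from compound 1 in one place: fluoro in place of methoxy on an aromatic carbon. For the measured compounds named here, no measured pair shows what this swap does in this assay, and the two measured compounds, which differ from each other elsewhere in the structure, give values within the scatter. The expectation is therefore for no step beyond the scatter, in either direction. Compound 3 is estimated at 4500 nM, with a range from 2200 nM to 9000 nM, which amounts to an expected step of no change at the digits printed from compound 1 to compound 3 (within the scatter).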

Compound 3, concentration for 50% growth inhibition: 6900 nM
Compound 3: middle estimate off by 1.5-fold (0.19 log units), on the low side; measured number inside the range.
By their numbers in this assay, from the lowest: compounds 1, 2 and 3 (each within the scatter of the next).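

In this assay, the swap gives a 1.5-fold higher number from compound 1 to compound 3 (0.19 log units; within the scatter) when fluoro takes the place of methoxy on the aromatic carbon para to a large group. For the compounds shown here, this is the only measured pair for this change, and it shows that a two-atom group with a hydrogen-bond acceptor can give way to a single fluorine, which has none, with no step beyond the scatter. Nothing measured here points to a reason for the size of this step.

One swap at one position cannot show how much variation this place accepts. Going by these compounds, whether an amine, a carboxylic acid or a longer chain such as butoxy on the same aromatic carbon would also stay within the scatter remains open, as does the result of leaving the ring with only hydrogen there.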